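The source may report more compounds than this note shows. Statements on the series, on what has been measured and on what is new or still open speak of the compounds shown alone.

Compound 1 `CS(=O)(=O)c1ccc(C(=O)N2CCC(C(=O)N3CCN(c4ccc(F)cc4)CC3)CC2)cc1[N+](=O)[O-]`; compound 2 `CC(C)N(C(=O)C1CCN(C(=O)c2ccc(S(C)(=O)=O)c([N+](=O)[O-])c2)CC1)C(C)C`; compound 3 `Cc1ccc(N2CCN(C(=O)CCNC(=O)c3ccc(S(C)(=O)=O)c([N+](=O)[O-])c3)CC2)cc1`; compound 4 `CN(Cc1ccccc1)C(=O)C1CCN(C(=O)c2ccc(S(C)(=O)=O)c([N+](=O)[O-])c2)CC1`, not yet measured.

In an ADME assay on HepG2 cells (Homo sapiens) for cytotoxicity, read by CellTiter-Glo and ATP content, with a stated time of 72 h (a higher number here means that more compound is needed for the effect, a lower number that less compound is needed), compound 1 gives > 27000 nM, which is a limit of the assay and not a number. In this assay compound 2 gives > 27000 nM, also a limit. In this assay compound 3 gives > 27000 nM, a limit as well. Compound 2 therefore stands at the same limit as the other two measured compounds, and no number sets it apart from them (the limit of > 27000 nM in this assay, at which 3 of the 3 values shown sit).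

Compound 4 differs from compound 2 in one place: benzyl(methyl)amino in place of diisopropylamino on a carbonyl carbon. Among the compounds with values here, no step between two measured compounds in this assay is available, so nothing among the measured values shows any change that this kind of exchange brings. Given that compound 2 sits at the limit, compound 4 is expected to sit there too, with a step that the limit leaves unreadable from compound 2 to compound 4 that amounts to nothing beyond the scatter. Compound 4 is estimated at 30000 nM in this assay, within a range from 10000 nM to 100000 nM, most likely reported again only as a limit.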

Compound 4, half-maximal effective concentration: > 27000 nM
Compound 4 was reported as a limit; the forecaster's own chance of this, stated with the estimate: 80%; the middle value does not contradict the limit.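

In this assay compound 4 gives > 27000 nM, a limit of the assay and not a number. Compound 2 also stands at a limit, so no step can be read between compound 2 and compound 4. The compounds shown leave open whether benzyl(methyl)amino and diisopropylamino differ at all in this assay, and at what concentration any of these compounds would reach the half-maximal effect.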